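Adding a Methoxy to the Benzyl Arm of Compound 3

The source may report more compounds than this note shows. Statements on the series, on what has been measured and on what is new or still open speak of the compounds shown alone.

Going by the values given here, compound 3 `C[C@H](NC(=O)c1c(-c2ccccc2)nnn1Cc1ccccc1)c1ccc(C(=O)O)cc1` is the one compound with a number: in a functional assay on CHO cells for antagonist activity at prostaglandin E2 receptor EP4 subtype (Homo sapiens), read by calcium flux, with a stated time of 15 min (on this read-out higher numbers stand for weaker inhibition and lower numbers for stronger inhibition), compound 3 gives 647 nM. Compound 1 `CCc1c(C(=O)N[C@@H](C)c2ccc(C(=O)O)cc2)nnn1Cc1ccc(C(F)(F)F)cc1` sits at a limit of this assay, giving > 10000 nM. Compound 2 `C[C@H](NC(=O)c1nnn(Cc2ccc(C(F)(F)F)cc2)c1-c1ccccc1)c1ccc(C(=O)O)cc1` likewise sits at a limit, giving > 10000 nM. The step that the two limits leave unreadable from compound 1 to compound 2 stays unreadable, the two limits being (the limit of > 10000 nM in this assay, at which 2 of the 3 values shown sit). Compound 4 `COc1ccc(Cn2nnc(-c3ccccc3)c2C(=O)N[C@@H](C)c2ccc(C(=O)O)cc2)cc1` differs from compound 3 by methoxy in place of hydrogen on an aromatic carbon; cut one bond further out, this reads phenyl to 4-methoxyphenyl, benzyl to 4-methoxybenzyl. No measured step touches this position, and the only step shown concerns a different place and cannot be read. The step expected in this assay, a 1.0-fold higher number from compound 3 to compound 4 (0.00 log units; within the scatter), is none beyond the scatter. Compound 4 is estimated at 650 nM, in the range 200 nM to 2500 nM.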

Compound 4, half-maximal inhibitory concentration: 9.3 nM
Estimate against measurement, compound 4: 70-fold (1.84 log units) above, outside the stated range (below it).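

In this assay, the benzyl arm turns out to be a place where a single small group counts: methoxy in place of hydrogen, para to a large group, gives a 70-fold lower number from compound 3 to compound 4 (1.84 log units; beyond the scatter). Going by these compounds alone, no earlier readable step touched this position, so this is the first measured sign of how strongly it responds. Nothing shown gives a cause for the step.

Open, going by these compounds, is whether an ethoxy, a hydroxyl or a chlorine on the same carbon would act like methoxy. Also open, on these data alone, is whether the step would persist with ethyl in place of the phenyl on the core.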